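The compounds below may be only part of what the source reports. "The series", "measured", "known", "first", "only" and "open" are said of these compounds alone.

- compound 1 `O=C1c2nccnc2C(=O)N1Cc1ccc(Cl)cc1` reads 88000 nM as a measured number
- compound 2 `O=C1c2nccnc2C(=O)N1Cc1ccccc1` reads > 100000 nM as a limit of the assay

In an ADME assay on Vero cells (Chlorocebus sabaeus) for cytotoxicity (on this read-out higher numbers stand for weaker inhibition and lower numbers for stronger inhibition), compound 1 gives 88000 nM as a number. Compound 2 stands at > 100000 nM as a limit and not a number, so only a limit is known for it. The reference point for what follows is the limit of > 100000 nM in this assay, at which 1 of the 2 values shown sits, and nothing firmer.

Compound 3 `CCN1C(=O)c2nccnc2C1=O` is the next case, with the change methyl in place of phenyl on a saturated chain carbon bound to an amide-type nitrogen in a ring and thus methyl in place of phenyl on a saturated chain carbon bound to an amide-type nitrogen in a ring. Among the compounds with values here, only one measured step is available: an at least 1.1-fold higher number from compound 1 to compound 2 (0.05 log units; that floor lies within the scatter) is a change of hydrogen in place of chloro on an aromatic carbon, and its floor lies within the scatter. Within the data shown here, no measured step removes the phenyl itself, so this evidence is indirect.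

No change beyond the scatter is therefore expected in this assay and the estimated step is a step that the limit leaves unreadable from compound 2 to compound 3 with the reading staying close to the limit. For compound 3 the estimated value is 120000 nM with a range from 60000 nM to 300000 nM and a report as a limit alone is the likelier outcome.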

Compound 3, half-maximal inhibitory concentration: > 100000 nM
Compound 3 was reported as a limit; the forecaster's own chance of this, stated with the estimate: 80%; the middle value does not contradict the limit.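

In this assay, compound 2 and compound 3 both stand as limits and not as numbers, and no new step can be read between them. The compounds shown leave open whether methyl in place of phenyl on a saturated chain carbon bound to an amide-type nitrogen in a ring changes this read-out at all, and by how much.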